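Phenyl for Butyl on the Carbamate Oxygen

The source may report more compounds than this note shows. Statements on the series, on what has been measured and on what is new or still open speak of the compounds shown alone.

Compound 1 `CCCCOC(=O)Nc1ccc([Se]C#N)cc1` was tested in an ADME assay on 184B5 cells (Homo sapiens) for cytotoxicity, read by MTT assay, with a stated time of 72 h (a lower number here means a stronger inhibitor of growth, a higher number a weaker inhibitor of growth), where compound 1 gives 14500 nM. Within the data shown here, the only other measured compound, compound 2 `O=C(Nc1ccc([Se][Se]c2ccc(NC(=O)OCc3ccc([N+](=O)[O-])cc3)cc2)cc1)OCc1ccc([N+](=O)[O-])cc1`, gives 13800 nM in this assay. Among the measured compounds shown here, these two values lie within the usual scatter of each other, so on the numbers so far compound 1 stands level with compound 2, and nothing can be said about which is the stronger growth inhibitor.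

Compound 3 `N#C[Se]c1ccc(NC(=O)Oc2ccccc2)cc1` has not yet been measured. It differs from compound 1 by phenyl in place of butyl on an oxygen next to a carbonyl group. For the measured compounds named here, compound 1 and compound 2 differ in many places at once, so no step involving a single structural change has been measured, and there is no direct guide to what this change will do. The expectation is that the step from compound 1 to compound 3 is a 1.2-fold lower number from compound 1 to compound 3 (0.08 log units; within the scatter), no larger than the scatter and in no firm direction, because compound 1 gives 14500 nM and compound 2 gives 13800 nM despite their large structural differences. Compound 3 is therefore expected to give 12000 nM in this assay, within a range of 5000 nM to 30000 nM.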

Compound 3, concentration for total growth inhibition: 22700 nM
Compound 3: the middle estimate sits 1.9-fold (0.28 log units) below what was measured; measured number inside the range.
By their numbers in this assay, from the lowest: compounds 2, 1 and 3 (each within the scatter of the next).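

In this assay, among these compounds, putting phenyl in place of butyl on an oxygen next to a carbonyl group gives a 1.6-fold higher number from compound 1 to compound 3 (0.19 log units; within the scatter), which is the first reading of a single structural change at this position. Swapping butyl, a chain with no ring, for phenyl, a six-membered aromatic ring of carbon only, therefore produces no difference that can be told apart from ordinary repeat-to-repeat variation in this assay, so this one change gives no sign that growth inhibition here depends on which of the two groups sits on the oxygen. Nothing in the available data speaks to how either group acts on these cells, so the result stands as an observation without an explanation.

As far as these compounds go, whether any other group on this oxygen would shift the number beyond the scatter remains open, for example a longer chain, a small methyl group, or a phenyl ring carrying an amine or a carboxylic acid. Compound 2 differs from compound 1 in many places at once, so it cannot help settle what this position tolerates.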